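The source may hold more compounds than are shown below. What is called first, only, known or untested is meant among the compounds shown, and "the series" means these compounds.

Working notes on the series.

In a functional assay on PC-3 cells (Homo sapiens) for inhibition, read by sulforhodamine B assay, with a stated time of 48 h (a lower number here means a stronger inhibitor, a higher number a weaker inhibitor), compound 3 `CCO[C@H]1C[C@@H](c2coc3ccc(C)cc3c2=O)N(c2ccccc2)O1` gives 39000 nM, the lowest of the three numbers, though within the scatter of compound 1 `O=c1c([C@@H]2C[C@H](c3ccccc3)ON2c2ccccc2)coc2ccc(F)cc12` at 49000 nM and of compound 2 `O=c1c([C@@H]2C[C@H](c3ccccc3)ON2c2ccccc2)coc2ccc(Br)cc12` at 60000 nM. For the measured compounds named here, the only single-point step measured so far, a 1.2-fold higher number from compound 1 to compound 2 (0.09 log units; within the scatter), concerns a halogen swap on the core and says nothing about the saturated ring. Compound 4 `Cc1ccc2occ([C@@H]3C[C@H](c4ccccc4)ON3c3ccccc3)c(=O)c2c1` differs from compound 3 by phenyl in place of ethoxy on a saturated ring carbon. Going by the values given here, no measured pair covers this change directly; compounds 1 and 2, which already carry that phenyl, sit within the scatter of compound 3, so no step beyond the scatter is expected in this assay. Compound 4 is therefore estimated at 45000 nM, range 20000 nM to 100000 nM, a step of a 1.2-fold higher number from compound 3 to compound 4 (0.06 log units; within the scatter).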

Compound 4, half-maximal inhibitory concentration: > 60000 nM
Compound 4: a limit, no number; the forecaster's own chance of this, stated with the estimate: 15%; at least 1.3-fold (0.12 log units) between middle value and limit.
By their numbers in this assay, from the lowest: compounds 3, 1 and 2 (each within the scatter of the next).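

Compound 4 reaches only a limit, not a number, in this assay: the limit of > 60000 nM in this assay, at which 1 of the 4 values shown sits. Phenyl in place of ethoxy on this saturated ring carbon gives an at least 1.5-fold higher number from compound 3 to compound 4 (0.18 log units; that floor lies within the scatter), the first direct reading at this position, and it shows no gain from phenyl here. The change from fluoro to methyl on an aromatic carbon gives an at least 1.2-fold higher number from compound 1 to compound 4 (0.08 log units; that floor lies within the scatter), and the change from bromo to methyl on an aromatic carbon gives a number no lower from compound 2 to compound 4 (the limit leaves the size open).

Going by these compounds, how far compound 4 lies past its limit stays open, so the true size of both floors is unknown. Also open, on these data alone, is how an amine, a carboxylic acid or a longer chain would read on this ring carbon.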